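The compounds below may be only part of what the source reports. "The series", "measured", "known", "first", "only" and "open" are said of these compounds alone.

Measured so far:
Compound 2 `CC(c1cc2cccnc2cc1F)n1cnc2ncc(-c3ccncc3)nc21` gives 171 nM in a functional assay on NCI-H1993 cells (Homo sapiens) for inhibition, read by CCK-8 assay, with a stated time of 72 h; a higher number here means a weaker inhibitor, a lower number a stronger inhibitor.
Compound 1 `CC(c1cc(F)c2ncccc2c1)n1cnc2ncc(-c3ccncc3)nc21` gives only a limit of the assay, > 10000 nM, in this assay.
Compound 3 `CC(c1cc(F)c2ncccc2c1)n1cnc2ncc(-c3ccccc3)nc21` also gives only a limit, > 10000 nM, in this assay.

Compound 1 and compound 2 are built from the same atoms joined differently; the difference between the two cores is not broken down here. Compound 3 arises from compound 1 by phenyl in place of pyridin-4-yl on an aromatic carbon. The step from compound 1 to compound 3 is a step that the two limits leave unreadable from compound 1 to compound 3, since both of its ends sit at the limit of > 10000 nM in this assay, at which 2 of the 3 values shown sit.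

Compound 4 `CC(c1cc2cccnc2cc1F)n1cnc2ncc(-c3ccccc3)nc21` has not yet been measured. It arises from compound 2 by phenyl in place of pyridin-4-yl on an aromatic carbon. The place around the change is described in the same words for compound 1 to compound 3 and for compound 2 to compound 4, so this is the same change made on a different core, and it occurs twice among the compounds shown. The earlier occurrence gives no readable size, so the only measured starting point is compound 2 at 171 nM in this assay.

Compound 4 is expected to sit at 800 nM in this assay, estimated between 170 nM and 10000 nM, which would mean an estimated step of a 4.7-fold higher number from compound 2 to compound 4 (0.67 log units; beyond the scatter).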

Compound 4, half-maximal inhibitory concentration: 570 nM
The estimate for compound 4 lay 1.4-fold (0.15 log units) above the measured number, and the stated range covers the measured number.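

In this assay, putting phenyl in place of pyridin-4-yl on the core of compound 2 gives a 3.3-fold higher number from compound 2 to compound 4 (0.52 log units; beyond the scatter). On this core, then, the change costs a measurable but modest amount, and the compound with phenyl still gives a readable number, so the ring nitrogen of pyridin-4-yl is not needed for a readable result here. This does not show that the change behaves the same way on another core, as the matching step on the core of compound 1 cannot be read, because both of its ends sit at a limit and not at a number: the limit of > 10000 nM in this assay, at which 2 of the 4 values shown sit.

The pair on the core of compound 2 is therefore the only readable case, and one pair cannot establish a trend that carries from core to core. At this place the compounds shown hold only pyridin-4-yl and phenyl, so it remains open how pyridin-3-yl, an aminomethyl group or a carboxylic acid would read in this assay, and whether any of them would give a stronger inhibitor than compound 2.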